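Fluoro for methoxy on the Vero cytotoxicity read-out

This account rests on a few compounds, and the source may have more. Where it says the series, first, only, none or still open, it means among the compounds named here.

Compound 1 `Fc1ccc(-c2nn3c(NC4CCCC4)nccc3c2-c2ccnc(NC3CCCC3)n2)cc1` and compound 2 `COc1ccc(-c2nn3c(NC4CCCC4)nccc3c2-c2ccnc(NC3CCCC3)n2)cc1` share one core. In an ADME assay on Vero cells (Chlorocebus sabaeus) for cytotoxicity (on this read-out higher numbers stand for lower toxicity in this test and lower numbers for higher toxicity in this test), compound 1 reaches only the limit > 40000 nM. In this assay compound 2 likewise reaches only the limit > 40000 nM. The change fluoro in place of methoxy on an aromatic carbon therefore gives a step that the two limits leave unreadable from compound 2 to compound 1, unreadable because the limit of > 40000 nM in this assay, at which 2 of the 3 values shown sit, covers both ends. Compound 3 `COc1ccc(-c2nn3c(NC4CCCC4)ccnc3c2-c2ccnc(NC3CCCC3)c2)cc1` carries a different core; the difference between the two cores is not broken down here. In this assay, going by the values given here, compound 3 gives 10000 nM, the only number among the three. Compound 4 `Fc1ccc(-c2nn3c(NC4CCCC4)ccnc3c2-c2ccnc(NC3CCCC3)c2)cc1` differs from compound 3 by fluoro in place of methoxy on an aromatic carbon, the same change as that from compound 2 to compound 1. With no readable step for this change, compound 4 is expected to stay close to compound 3 at 10000 nM, an estimated step of a 1.2-fold higher number from compound 3 to compound 4 (0.08 log units; within the scatter). For compound 4 the estimate is 12000 nM, between 4000 nM and 40000 nM.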

Compound 4, half-maximal cytotoxic concentration: 16000 nM
Estimate against measurement, compound 4: 1.3-fold (0.12 log units) below; the range from low to high includes it.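

In this assay, fluoro in place of methoxy gives a 1.6-fold higher number from compound 3 to compound 4 (0.20 log units; within the scatter), so on this core the two compounds cannot be told apart. On the core of compounds 1 and 2 the same change cannot be read, because both ends sit at a limit: the limit of > 40000 nM in this assay, at which 2 of the 4 values shown sit.

The series therefore offers one readable step for this change, which shows nothing against carrying it over to the second core but does not show that its size is the same on both.

From the compounds shown here alone, only 4-methoxyphenyl and 4-fluorophenyl appear at this place, so how an amine or a carboxylic acid there would read remains open. Also open, going by these compounds, is which part of the difference between the two cores goes with the values in this read-out.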